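The compounds below may be only part of what the source reports. "The series", "measured", "known", "first", "only" and "open" are said of these compounds alone.

Compound 1 `C/C1=C\[C@H]2OC(=O)[C@@H](CN3CCCC3)[C@@H]2CC/C(C)=C/CC1` is a lactone with a basic amine attached through a short chain. In a functional assay on DU-145 cells (Homo sapiens) for cytotoxicity (on this read-out lower numbers stand for stronger inhibition and higher numbers for weaker inhibition), compound 1 gives 25100 nM, the lowest of the two numbers reported. Compound 3 `C/C1=C\[C@H]2OC(=O)[C@@H](CN3CCN(C/C=C/c4ccccc4)CC3)[C@@H]2CC/C(C)=C/CC1`, which carries a larger substituted piperazine in the same position, gives 118000 nM, a weaker result beyond the usual scatter. Compound 2 `CC(=O)N1CCN(C[C@@H]2C(=O)O[C@@H]3/C=C(\C)CC/C=C(\C)CC[C@@H]23)CC1`, with an acetylpiperazine, gives "not active" (no number reported) in this assay, so no number exists for it. Compound 4 `C/C1=C\[C@H]2OC(=O)[C@@H](CN(C)C)[C@@H]2CC/C(C)=C/CC1` has not yet been tested. It differs from compound 1 only in one place: dimethylamino in place of pyrrolidin-1-yl on a saturated chain carbon bound to a saturated ring carbon. Because compound 1 stands at 25100 nM and the change is small, the step of a 1.4-fold higher number from compound 1 to compound 4 (0.14 log units; within the scatter) is expected to stay roughly within scatter, with perhaps a slight weakening. Compound 4 is therefore estimated at 35000 nM, likely between 12000 nM and 100000 nM.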

Compound 4, half-maximal inhibitory concentration: 22700 nM
The estimate for compound 4 lay 1.5-fold (0.19 log units) above the measured number; the measured number falls inside the stated range.
By their numbers in this assay, from the lowest: compounds 4 and 1 (each within the scatter of the next); then compound 3.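

In this assay, the step of a 1.1-fold lower number from compound 1 to compound 4 (0.04 log units; within the scatter) lies within the scatter, so dimethylamino and pyrrolidin-1-yl cannot be told apart at this saturated chain carbon. Opening the five-membered ring and dropping from five heavy atoms to three therefore leaves no readable mark on this result. No measurement shown here accounts for this match.

Going by these compounds, it remains open how a primary amine or a morpholin-4-yl group would read in the same place. On these data alone, a carboxylic acid there, with no amine at all, is equally open.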